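Swapping an ethoxy for butylsulfanyl on a non-toxic core

A few compounds are considered here, and "the series" means these few. Any claim that something is new, unique, unknown or untested is made for them only; others in the source may bear on it.

Compound 1 `CCOc1nc(N)nc2c1ncn2/C=C1/CC1(CO)CO` is the starting point. In an ADME assay on CCRF-HSB-2 cells (Homo sapiens) for cytotoxicity, with a stated time of 7 days (a lower number here means that less compound is tolerated, a higher number that more compound is tolerated), compound 1 shows only a limit of the assay, > 20000 nM. Compound 2 `CCCCCCCCOc1nc(N)nc2c1ncn2/C=C1/CC1(CO)CO` likewise reaches only a limit, > 20000 nM. Compound 3 `Nc1nc(OCc2ccccc2)c2ncn(/C=C3/CC3(CO)CO)c2n1` also stops at a limit, > 20000 nM. The steps a step that the two limits leave unreadable from compound 1 to compound 2 and a step that the two limits leave unreadable from compound 1 to compound 3 therefore cannot be read. Compound 4 `CCCCSc1nc(N)nc2c1ncn2/C=C1/CC1(CO)CO` carries the change (butylsulfanyl in place of ethoxy on an aromatic carbon). Within the data shown here, none of the measured steps can be sized, yet the shared core has tolerated every chain tried, due to the limit of > 20000 nM in this assay, at which 3 of the 3 values shown sit. The step from compound 1 to compound 4 is expected to stay at this limit, a step that the limit leaves unreadable from compound 1 to compound 4. Compound 4 is estimated at 40000 nM, within 20000 nM to 100000 nM.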

Compound 4, half-maximal cytotoxic concentration: 89000 nM
Estimate against measurement, compound 4: 2.2-fold (0.35 log units) below; the measured number falls inside the stated range.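

Among these compounds, compounds 1, 2 and 3 each reach only a limit of the assay, so no step from any of them to compound 4 can be read. The compounds shown leave open whether butylsulfanyl in place of ethoxy makes any real difference in this assay.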